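Trading Iodo for Fluoro on the Weaker Inhibitor

This account rests on a few compounds, and the source may have more. Where it says the series, first, only, none or still open, it means among the compounds named here.

Of the compounds shown here, two have numbers so far in a physicochemical assay, with a stated time of 6 min (a lower number here means a stronger inhibitor, a higher number a weaker inhibitor), and they lie far apart. Compound 1 (`O=C(Nc1ccc(F)cc1)Nc1nc(-c2cc3ccccc3o2)cs1`) gives 1130 nM as its half-maximal inhibitory concentration. Compound 2 (`O=C(Nc1ccc(I)cc1)Nc1nc(-c2cc3cc([N+](=O)[O-])ccc3o2)cs1`) gives 62400 nM on the same read-out, the higher of the two numbers by a margin well beyond the scatter, which makes it the weaker inhibitor of the pair. These two compounds differ in more than one place, so their gap cannot be assigned to any single change.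

Compound 3 (`O=C(Nc1ccc(F)cc1)Nc1nc(-c2cc3cc([N+](=O)[O-])ccc3o2)cs1`) is still unmeasured. It departs from compound 2 at one place, with fluoro in place of iodo on an aromatic carbon. Going by the values given here, no measured step isolates this change. Compound 3 shares its 4-fluorophenyl with compound 1 at 1130 nM and keeps the rest of compound 2 at 62400 nM as well. A moderate move towards a lower number is therefore expected, and the estimated change is a 5.2-fold lower number from compound 2 to compound 3 (0.72 log units; beyond the scatter) in this assay with real uncertainty. For compound 3 the estimated value is 12000 nM with an expected range from 2000 nM to 60000 nM in this measurement.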

Compound 3, half-maximal inhibitory concentration: 123000 nM
Estimate against measurement, compound 3: 10-fold (1.01 log units) below; the measured number lies above the stated range.
By their numbers in this assay, from the lowest: compound 1; then compounds 2 and 3 (each within the scatter of the next).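

In this assay, the exchange of iodo for fluoro on the six-membered aromatic ring gives a 2.0-fold higher number from compound 2 to compound 3 (0.29 log units; within the scatter), so on the core that carries the nitro group this change at this position separates the two halogens by no more than the scatter. The first single-place step to stand beyond the scatter is the other one, nitro in place of hydrogen on an aromatic carbon, which gives a 110-fold higher number from compound 1 to compound 3 (2.04 log units; beyond the scatter) and is large; among the compounds shown, this is the change with a clear effect on the number, while the halogen exchange has none that can be read. Nothing at hand speaks to what lies behind either step.

Still open, as far as these compounds go, is whether fluoro and iodo would also lie within the scatter of each other on the core without the nitro group, and so whether the two changes act independently. Also open, from the compounds shown here alone, is how an amine or a carboxylic acid in place of the nitro group would read in this assay.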